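The source may hold more compounds than are shown below. What is called first, only, known or untested is meant among the compounds shown, and "the series" means these compounds.

Measured compounds:

- compound 1 `Nc1scc(CN2CCN(c3cccc(C(F)(F)F)c3)CC2)c1C(=O)c1ccc(Cl)cc1` in an assay on CHO cells for displacement of a labelled ligand from adenosine receptor A1 (Homo sapiens), read by scintillation counting, with a stated time of 120 min, tested at 10 uM (on this read-out lower numbers stand for less inhibition and higher numbers for more inhibition at the one concentration tested (going by the name of the read-out)), gives 0%
- compound 2 `Nc1scc(CN2CCN(c3c(F)cc(F)cc3F)CC2)c1C(=O)c1ccc(Cl)cc1` in this assay gives 0%
- compound 3 `Nc1scc(CN2CCN(c3ccc(F)c(Cl)c3)CC2)c1C(=O)c1ccc(Cl)cc1` in this assay gives 0%

Compound 3 stands level with compound 1 and compound 2 at the digits printed; its nearest neighbour is compound 1 and its furthest is compound 2, and neither gap is beyond the scatter. The three steps among the measured compounds all read flat: no change at the digits printed from compound 1 to compound 2 (within the scatter), no change at the digits printed from compound 1 to compound 3 (within the scatter) and no change at the digits printed from compound 2 to compound 3 (within the scatter). Every exchange of the group on the ring nitrogen so far has left the read-out unchanged.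

Compound 4 `Nc1scc(CN2CCN(c3cc(Cl)ccc3Cl)CC2)c1C(=O)c1ccc(Cl)cc1` is not yet measured. It differs from compound 3 in one place:

2,5-dichlorophenyl in place of 3-chloro-4-fluorophenyl on an amine nitrogen in a ring

Among the compounds with values here, the steps that bear on this are the three above, each a change of the same group at the same position, each within the scatter. On that basis no step beyond the scatter is expected for the new exchange; the step of no change at the digits printed from compound 3 to compound 4 (within the scatter) is the estimate. Compound 4 is therefore expected to give 0%, with a range from -10% to 12%.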

Compound 4, a percentage reported as inhibition, at one concentration (the size of the read-out at that concentration, not a potency): 0%
Compound 4: middle estimate and measured number agree at the digits printed; the measured number falls inside the stated range.
By their numbers in this assay, from the lowest: compounds 1, 2, 3 and 4 (each within the scatter of the next).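

In this assay the exchange to 2,5-dichlorophenyl on the amine nitrogen in the ring reads flat against all three earlier groups (no change at the digits printed from compound 3 to compound 4 (within the scatter); no change at the digits printed from compound 2 to compound 4 (within the scatter); no change at the digits printed from compound 1 to compound 4 (within the scatter)). Within the data shown here, this is the first group at this position that carries chlorine and no fluorine, so the flat reading no longer rests only on groups containing fluorine. No measured evidence bears on why the reading stays flat.

From the compounds shown here alone, whether any group on this nitrogen can lift the reading stays open, for example a phenyl bearing a carboxylic acid or an amine, or a pyridine ring in place of the phenyl. Going by these compounds, all four compounds also share the same core, so the effect of a change elsewhere in it remains unknown.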